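Fluorine on the Fused Ring and Antiproliferative Potency

A few compounds are considered here, and "the series" means these few. Any claim that something is new, unique, unknown or untested is made for them only; others in the source may bear on it.

Measured compounds:
compound 1, `CS(=O)(=O)c1ccc(Nc2ncc(F)c(Nc3nc4ccccc4s3)n2)cc1`, 2830 nM
compound 2, `CS(=O)(=O)c1ccc(Nc2ncc(F)c(Nc3nc4ccc(F)cc4s3)n2)cc1`, > 50000 nM
compound 3, `NS(=O)(=O)c1ccc(Nc2nccc(Nc3nc4ccccc4s3)n2)cc1`, 3100 nM

In a functional assay on PC-3 cells (Homo sapiens) for antiproliferative activity, read by MTT assay, with a stated time of 48 h (on this read-out higher numbers stand for weaker inhibition and lower numbers for stronger inhibition), compound 1 gives 2830 nM. Compound 2 reaches only the limit of the assay, > 50000 nM. The step of an at least 17-fold higher number from compound 1 to compound 2 (1.24 log units; beyond the scatter) corresponds to fluoro in place of hydrogen on an aromatic carbon. Compound 3 gives 3100 nM in this assay; the difference between its core and that of compound 1 is not broken down here. Compound 4, `NS(=O)(=O)c1ccc(Nc2nccc(Nc3nc4ccc(F)cc4s3)n2)cc1`, is not yet measured and differs from compound 3 by fluoro in place of hydrogen on an aromatic carbon, the same change as before. A step of a 9.7-fold higher number from compound 3 to compound 4 (0.99 log units; beyond the scatter) is expected, because an at least 17-fold higher number from compound 1 to compound 2 (1.24 log units; beyond the scatter) was large and because the limit of > 50000 nM in this assay, at which 1 of the 3 values shown sits, marks where compound 2 sat. Compound 4 is therefore expected to give about 30000 nM in this assay.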

Compound 4, half-maximal inhibitory concentration: 920 nM
For compound 4 the middle estimate is 33-fold (1.51 log units) above the measured one; the measured number lies below the stated range.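

In this assay, fluoro in place of hydrogen on an aromatic carbon gave a 3.4-fold lower number from compound 3 to compound 4 (0.53 log units; beyond the scatter), the opposite direction to the earlier step, so this change did not carry from one core to the other: the same change on two cores in this assay, an at least 17-fold higher number (1.24 log units; beyond the scatter) from compound 1 to compound 2 and a 3.4-fold lower number (0.53 log units; beyond the scatter) from compound 3 to compound 4, at least 59-fold (1.77 log units) apart, beyond the scatter of two such steps. Compound 2 gives > 50000 nM, which is a limit of the assay and not a number: the limit of > 50000 nM in this assay, at which 1 of the 4 values shown sits. These two pairs do not show which difference between the cores goes with the reversal, and they establish no rule for the series.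

On these data alone, it remains open whether chloro or methoxy on the same aromatic carbon would follow the direction seen with fluoro on either core. As far as these compounds go, what an amine or a carboxylic acid there would give also remains open.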